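Swapping the benzyl substituent on the amide of compound 3

The compounds below may be only part of what the source reports. "The series", "measured", "known", "first", "only" and "open" are said of these compounds alone.

Of the compounds shown here, three sharing one core have been measured in an assay on microsomes from liver for inhibition of 3-hydroxy-3-methylglutaryl-coenzyme A reductase (Rattus norvegicus); a higher number here means a weaker inhibitor, a lower number a stronger inhibitor. Compound 1 `CC(C)c1c(C(=O)NCC2CCCCC2)nn(-c2ccc(F)cc2)c1OC[C@@H](O)C[C@@H](O)CC(=O)O` carries a (cyclohexylmethyl)amino group on the carbonyl carbon and gives 17 nM. Compound 2 `CC(C)c1c(C(=O)N2CCCCC2)nn(-c2ccc(F)cc2)c1OC[C@@H](O)C[C@@H](O)CC(=O)O` has piperidin-1-yl in its place and gives 47 nM; the step of a 2.8-fold higher number from compound 1 to compound 2 (0.44 log units; beyond the scatter) is modest but beyond the scatter. Compound 3 `COc1cccc(CNC(=O)c2nn(-c3ccc(F)cc3)c(OC[C@@H](O)C[C@@H](O)CC(=O)O)c2C(C)C)c1` bears a (3-methoxybenzyl)amino group and gives 16 nM. For the measured compounds named here, compound 3 shows the lowest of the three numbers, but its gap to compound 1, a 1.1-fold lower number from compound 1 to compound 3 (0.03 log units; within the scatter), lies within the scatter, so the two cannot be ordered; only the step of a 2.9-fold lower number from compound 2 to compound 3 (0.47 log units; beyond the scatter) separates compound 3 from compound 2.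

Compound 4 `CC(C)c1c(C(=O)NCc2ccccc2Cl)nn(-c2ccc(F)cc2)c1OC[C@@H](O)C[C@@H](O)CC(=O)O` differs from compound 3 by 2-chlorophenyl in place of 3-methoxyphenyl on a saturated chain carbon bound to an amide-type nitrogen. Going by the values given here, the one measured step that bears on a change at this carbon is a 1.1-fold lower number from compound 1 to compound 3 (0.03 log units; within the scatter), where replacing cyclohexyl by 3-methoxyphenyl left the number unchanged within the scatter. Among the compounds with values here, no measured pair compares a chlorine-bearing ring with a methoxy-bearing ring, so that part of the change has no precedent here. On this basis the estimated step is a 1.1-fold higher number from compound 3 to compound 4 (0.03 log units; within the scatter), expected to stay within the scatter. Compound 4 is therefore expected to give about 17 nM in this assay, with a range from 7 nM to 45 nM.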

Compound 4, half-maximal inhibitory concentration: 9.5 nM
Compound 4: middle estimate off by 1.8-fold (0.25 log units), on the high side; the measured number falls inside the stated range.
By their numbers in this assay, from the lowest: compounds 4, 3 and 1 (each within the scatter of the next); then compound 2.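

In this assay, a chlorine-bearing ring on the saturated chain carbon bound to an amide-type nitrogen fits with the two groups already seen there: both a 1.7-fold lower number from compound 3 to compound 4 (0.23 log units; within the scatter) and a 1.8-fold lower number from compound 1 to compound 4 (0.25 log units; within the scatter) lie within the scatter, so compound 1, compound 3 and compound 4 cannot be ordered. The new compound also widens the separation from the piperidin-1-yl amide, since a 4.9-fold lower number from compound 2 to compound 4 (0.69 log units; beyond the scatter) lies beyond the scatter, and all three compounds with a ring on that saturated chain carbon now have lower numbers than compound 2, with none going against this. No measurement to hand explains why the 2-chlorophenyl group reads as it does.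

Because the two aromatic rings differ in both substituent and its place, the compounds shown cannot separate the effect of exchanging methoxy for chlorine from the effect of moving the substituent. They also leave open how this assay this assay would read an unsubstituted benzyl group, or a benzyl ring carrying a nitrile or an amine, on the same amide.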